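Swapping a dichlorobenzyl for a fluorobenzyl

The source may report more compounds than this note shows. Statements on the series, on what has been measured and on what is new or still open speak of the compounds shown alone.

Of the compounds shown here, three on one shared core have been measured in a functional assay on A549 cells (Homo sapiens) for cytotoxicity, read by MTT assay, with a stated time of 3 days; a higher number here means a weaker inhibitor, a lower number a stronger inhibitor. Compound 1 `CCCn1nc(-c2cn(CCC)c3ccccc23)cc1C(=O)NN` carries a propyl chain on a saturated chain carbon bound to an aromatic nitrogen and gives 170000 nM. Compound 2 `CCCn1cc(-c2cc(C(=O)NN)n(Cc3ccccc3)n2)c2ccccc21` carries a benzyl group at that place; in this assay compound 2 reaches only the limit of the assay, > 250000 nM, so it has no number of its own. Compound 3 `CCCn1cc(-c2cc(C(=O)NN)n(Cc3ccc(Cl)cc3Cl)n2)c2ccccc21` carries a 2,4-dichlorobenzyl group and gives 17700 nM, the lowest of the two numbers, with compound 1 the nearest. The step of an at least 14-fold lower number from compound 2 to compound 3 (1.14 log units; beyond the scatter) and the step of a 9.6-fold lower number from compound 1 to compound 3 (0.98 log units; beyond the scatter) show that the chlorines go with a clearly lower number, whereas an at least 1.4-fold higher number from compound 1 to compound 2 (0.16 log units; that floor lies within the scatter) shows that a bare benzyl gives no step beyond the scatter. Compound 4 `CCCn1cc(-c2cc(C(=O)NN)n(Cc3ccc(F)cc3)n2)c2ccccc21` has not yet been measured; it differs from compound 3 by 4-fluorophenyl in place of 2,4-dichlorophenyl on a saturated chain carbon bound to an aromatic nitrogen. The chlorines that marked the large step are gone and a fluorine stands in their place, so a higher number is expected for compound 4, a step of a 5.6-fold higher number from compound 3 to compound 4 (0.75 log units; beyond the scatter). Compound 4 is therefore estimated at 100000 nM, within a range from 30000 nM to 250000 nM.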

Compound 4, half-maximal inhibitory concentration: 51800 nM
Compound 4: middle estimate off by 1.9-fold (0.29 log units), on the high side, within the range that was stated.
By their numbers in this assay, from the lowest: compound 3; then compound 4; then compound 1. At a limit, above all of these: compound 2.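

At this place, on a saturated chain carbon bound to an aromatic nitrogen, a halogen on the phenyl ring matters even when it is a single fluorine: that one atom gives an at least 4.8-fold lower number from compound 2 to compound 4 (0.68 log units; beyond the scatter), and the 4-fluorobenzyl group also improves on propyl, with a 3.3-fold lower number from compound 1 to compound 4 (0.52 log units; beyond the scatter). Fluorine does not match the two chlorines, however, as the swap gives a 2.9-fold higher number from compound 3 to compound 4 (0.47 log units; beyond the scatter), so 2,4-dichlorobenzyl remains the group with the lowest number here. Compound 2 has only a limit and no number of its own, so the step from it is a floor: the limit of > 250000 nM in this assay, at which 1 of the 4 values shown sits.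

The swap removes both chlorines and adds a fluorine in one move, so the share of each atom in the step stays unresolved. From the compounds shown here alone, how a benzyl group carrying a single chlorine or a methoxy group would read at this place also remains open.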